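This account rests on a few compounds, and the source may have more. Where it says the series, first, only, none or still open, it means among the compounds named here.

Measured compounds:
compound 2, `CN1CCN(C(=S)SCc2coc3ccccc3c2=O)CC1`: 2200 nM
compound 1, `COc1ccc2occ(CSC(=S)N3CCOCC3)c(=O)c2c1`: > 40000 nM

Within the data shown here, in a functional assay on MDA-MB-435S cells (Homo sapiens) for antiproliferative activity, read by MTT assay, with a stated time of 72 h (on this read-out higher numbers stand for weaker inhibition and lower numbers for stronger inhibition), compound 2 gives 2200 nM, and this is the only actual number in the set. Compound 1 gives > 40000 nM in this assay, which is a limit rather than a number. Among the measured compounds shown here, that limit is the point at which one of the two values sits (the limit of > 40000 nM in this assay, at which 1 of the 2 values shown sits), so compound 2 stands alone as the single compound with a measured concentration.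

The unmeasured compound 3, `O=c1c(CSC(=S)N2CCOCC2)coc2ccccc12`, is reached from compound 2 by a single change: morpholin-4-yl in place of 4-methylpiperazin-1-yl on a thiocarbonyl carbon. For the measured compounds named here, compound 1 also carries a morpholin-4-yl on its thiocarbonyl carbon, though it differs from compound 3 elsewhere as well, so no direct step between them can be drawn; its value only shows that a compound bearing this group reached no number in this assay.

Going by the values given here, with no measured step to lean on, the expectation for compound 3 rests on that comparison alone. Compound 3 is therefore estimated at 15000 nM, within 4000 nM to 45000 nM. The step this estimate means, from compound 2 to compound 3, is expected to be a loss of potency beyond the usual scatter, of about a 6.8-fold higher number from compound 2 to compound 3 (0.83 log units; beyond the scatter), with a real chance that only a limit is reported.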

Compound 3, half-maximal inhibitory concentration: 3900 nM
The estimate for compound 3 lay 3.8-fold (0.59 log units) above the measured number, outside the stated range (below it).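

In this assay, the exchange on the thiocarbonyl carbon now has a measured step, a 1.8-fold higher number from compound 2 to compound 3 (0.25 log units; within the scatter), so morpholin-4-yl and 4-methylpiperazin-1-yl cannot be told apart at this place, and morpholin-4-yl alone does not account for the lack of a number for compound 1. With morpholin-4-yl held fixed, the difference moves to the aromatic carbon, where hydrogen in place of methoxy gives an at least 10-fold lower number from compound 1 to compound 3 (1.01 log units; beyond the scatter). The figure for compound 1 in that step is a limit and not a number: the limit of > 40000 nM in this assay, at which 1 of the 3 values shown sits.

The compounds shown leave open whether an open-chain amine such as diethylamine, or a ring such as piperidine, on the thiocarbonyl carbon would stay level with these two groups. From the compounds shown here alone, each change also rests on a single pair, so it remains open whether methoxy on the aromatic carbon would give a similar step with 4-methylpiperazin-1-yl in place, and whether a fluorine or a hydroxyl there would read like hydrogen or like methoxy.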